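Notes on the carbonyl-to-sulfonyl change at the ring nitrogen

The source may hold more compounds than are shown below. What is called first, only, known or untested is meant among the compounds shown, and "the series" means these compounds.

In a functional assay on NCI-H1975 cells (Homo sapiens) for inhibition, read by sulforhodamine B assay, tested at 10 uM (on this read-out lower numbers stand for less inhibition and higher numbers for more inhibition at the one concentration tested (going by the name of the read-out)), compound 1 `CN(C)c1ccc(C2CC(c3ccc(-n4cncn4)cc3)=NN2C(=O)CCCl)cc1` gives -0.7%, compound 2 `COC(=O)CC(=O)N1N=C(c2ccc(-n3cncn3)cc2)CC1c1ccc(N(C)C)cc1` gives 1.5%, and compound 3 `CN(C)c1ccc(C2CC(c3ccc(-n4cncn4)cc3)=NN2C(=O)c2cc(Cl)cc(Cl)c2)cc1` gives 8.4%. Compound 3 holds the highest of the three numbers, yet its steps from compound 2 a number 6.9 percentage points higher from compound 2 to compound 3 (within the scatter) and from compound 1 a number 9.1 percentage points higher from compound 1 to compound 3 (within the scatter) both lie within the scatter, as does a number 2.2 percentage points higher from compound 1 to compound 2 (within the scatter). Compound 4 `CN(C)c1ccc(C2CC(c3ccc(-n4cncn4)cc3)=NN2S(=O)(=O)c2ccc(Br)cc2)cc1` differs from compound 3 by (4-bromophenyl)sulfonyl in place of (3,5-dichlorophenyl)carbonyl on an amine nitrogen in a ring. Every measured step varied the group on the carbonyl carbon while keeping the carbonyl itself; none exchanged the carbonyl for a sulfonyl, so they bear on this step only loosely, and all were within the scatter. No step beyond the scatter is therefore expected in this assay. Compound 4 is estimated at 5% with a range of -10% to 22%, an expected step of a number 3.4 percentage points lower from compound 3 to compound 4 (within the scatter).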

Compound 4, a percentage reported as inhibition, at one concentration (the size of the read-out at that concentration, not a potency): -0.6%
Compound 4: the middle estimate sits 5.6 percentage points above what was measured, and the stated range covers the measured number.
By their numbers in this assay, from the lowest: compounds 1, 4, 2 and 3 (each within the scatter of the next).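

In this assay, going by these compounds alone, the first exchange of carbonyl for sulfonyl on this ring nitrogen stays within the scatter: a number 9 percentage points lower from compound 3 to compound 4 (within the scatter), a number 2.1 percentage points lower from compound 2 to compound 4 (within the scatter), and a number 0.1 percentage points higher from compound 1 to compound 4 (within the scatter). The sulfonyl compound 4 therefore cannot be told apart from the three carbonyl compounds at this one concentration. No measured evidence bears on this result.

Open, from the compounds shown here alone, is whether a (3,5-dichlorophenyl)sulfonyl group, which would separate the sulfonyl from the change of halogens, reads differently from compound 3. Also open, going by these compounds, is whether an aminoalkyl chain on this nitrogen gives any step beyond the scatter.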